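Working notes on the series: from compound 2 to compound 3

The compounds below may be only part of what the source reports. "The series", "measured", "known", "first", "only" and "open" are said of these compounds alone.

Of the compounds shown here, two have been measured. Compound 1 `Cc1ccc(CN2CC(=O)N(Cc3ccc(C(=O)NO)cc3)C2=O)cc1` gives 17.6 nM in an assay on isolated protein for inhibition of protein deacetylase HDAC6 (Homo sapiens), read by fluorescence, with stated times of 10 min and 2 h; on this read-out higher numbers stand for weaker inhibition and lower numbers for stronger inhibition. Compound 2 `CC1(c2ccccc2)NC(=O)N(Cc2ccc(C(=O)NO)cc2)C1=O` gives 74.9 nM in this assay. Compound 2 stands at the higher of the two numbers; the nearest, compound 1, sits at a lower number by a gap beyond the usual scatter, so compound 2 is the weaker inhibitor of this pair.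

Compound 3 `O=C(NO)c1ccc(CN2C(=O)NC(Cc3ccc(Cl)cc3)(c3ccccc3)C2=O)cc1` is not yet measured. It differs from compound 2 in one place: 4-chlorophenyl in place of hydrogen on a saturated chain carbon bound to a saturated ring carbon. Among the compounds with values here, no measured pair shows this change, so its effect in this assay is open. Lacking any comparable step, the expected move for a 1.5-fold lower number from compound 2 to compound 3 (0.18 log units; within the scatter) is small, from none beyond the scatter to a modest shift toward a lower number. Compound 3 is therefore estimated at 50 nM in this assay, with a range from 15 nM to 160 nM.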

Compound 3, half-maximal inhibitory concentration: 54 nM
Compound 3: the middle estimate sits 1.1-fold (0.03 log units) below what was measured, within the range that was stated.
By their numbers in this assay, from the lowest: compound 1; then compounds 3 and 2 (each within the scatter of the next).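

Within the data shown here, the step of a 1.4-fold lower number from compound 2 to compound 3 (0.14 log units; within the scatter) in this assay is the first reading at this position: a saturated chain carbon bound to a saturated ring carbon can carry 4-chlorophenyl, which adds 7 heavy atoms and one aromatic ring, without a step beyond the scatter. Cut one bond further out, the same change reads methyl to 4-chlorobenzyl, so the number does not separate these two groups on this read-out. No evidence on the cause of this result is available.

On these data alone, whether an amine, a carboxylic acid or a longer chain at this place would give a step beyond the scatter remains open. As far as these compounds go, the part played by the chlorine also remains open, and a plain benzyl group in place of 4-chlorobenzyl would be needed to read it.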